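Carbamate Oxazolines: Cyclopentyl to Cyclohexyl Step

The source may hold more compounds than are shown below. What is called first, only, known or untested is meant among the compounds shown, and "the series" means these compounds.

Measured compounds:
Compound 1, `O=C(NC1CCCCC1)Oc1cccc(C2=NCCO2)c1`: 1.2 nM
Compound 2, `CC1(C)COC(c2cccc(OC(=O)NC3CCCC3)c2)=N1`: 65 nM

In an assay (strain Wistar) for inhibition of Fatty-acid amide hydrolase 1 (Rattus norvegicus), read by scintillation counting (on this read-out lower numbers stand for stronger inhibition and higher numbers for weaker inhibition), compound 1 gives 1.2 nM and compound 2 gives 65 nM. Compound 2 therefore stands at the higher of the two numbers, with compound 1 at a lower number, a gap described as beyond the scatter. The two compounds differ in more than one place, so nothing further is drawn from that pair.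

Compound 3, `CC1(C)COC(c2cccc(OC(=O)NC3CCCCC3)c2)=N1`, is not yet measured in this assay. It differs from compound 2 in a single change: cyclohexyl in place of cyclopentyl on an amide-type nitrogen. Compound 1 carries the same cyclohexylamino group and gives the lower number, so compound 3 is expected to give a lower number than compound 2, a step of a 3.3-fold lower number from compound 2 to compound 3 (0.51 log units; beyond the scatter), moderate in size but beyond the scatter. Compound 3 is thus estimated at 20 nM, within a range from 5 nM to 80 nM.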

Compound 3, half-maximal inhibitory concentration: 46 nM
Estimate against measurement, compound 3: 2.3-fold (0.36 log units) below; measured number inside the range.
By their numbers in this assay, from the lowest: compound 1; then compounds 3 and 2 (each within the scatter of the next).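

In this assay, cyclohexyl in place of cyclopentyl on an amide-type nitrogen gives a 1.4-fold lower number from compound 2 to compound 3 (0.15 log units; within the scatter), so this change does not separate the two compounds when the larger group sits on the aromatic carbon. With the cyclohexylamino group held constant, the exchange of the group on the aromatic carbon gives a 38-fold higher number from compound 1 to compound 3 (1.58 log units; beyond the scatter), a large step in one place that the first pair, differing in more than one place, could not isolate. Nothing given here bears on why either step has the size it does.

Going by these compounds, it remains open whether the cyclopentyl to cyclohexyl step would read the same with the group on the aromatic carbon of compound 1. On these data alone, how a phenyl ring or a straight hexyl chain on that nitrogen would compare also remains open.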